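This account rests on a few compounds, and the source may have more. Where it says the series, first, only, none or still open, it means among the compounds named here.

In a functional assay on aorta (Rattus norvegicus), in the presence of a further agent that is not named here (a higher number here means a weaker inhibitor, a lower number a stronger inhibitor), compound 1 (`CC1(C)CN(C2=CCCC2=O)c2cc([N+](=O)[O-])ccc2S1`) gives 417 nM, within the scatter of compound 3 (`CC1(C)CN(NC(=O)c2cccc(F)c2)c2cc([N+](=O)[O-])ccc2S1`) at 302 nM, while compound 2 (`CC(=O)NN1CC(C)(C)Sc2ccc([N+](=O)[O-])cc21`) gives a clearly lower 93.3 nM. Compound 4 (`CC1(C)CN(C2=CCCC2=O)c2cc(C(F)(F)F)ccc2S1`) has trifluoromethyl in place of nitro on an aromatic carbon. Among the measured compounds shown here, no measured step touches this place. For the measured compounds named here, both a 4.5-fold lower number from compound 1 to compound 2 (0.65 log units; beyond the scatter) and a 3.2-fold higher number from compound 2 to compound 3 (0.51 log units; beyond the scatter) change the group on the nitrogen, and all three measured compounds carry nitro, so these steps show only that changes elsewhere in this small set have been modest. As far as these compounds go, with no direct evidence on this exchange, no shift beyond the scatter is expected in this assay, and either direction remains open. The expected step is a 1.0-fold lower number from compound 1 to compound 4 (0.02 log units; within the scatter). For compound 4 the estimated value is 400 nM, with an expected range of 120 nM to 1300 nM.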

Compound 4, half-maximal inhibitory concentration: 437 nM
Estimate against measurement, compound 4: 1.1-fold (0.04 log units) below, within the range that was stated.
By their numbers in this assay, from the lowest: compound 2; then compounds 3, 1 and 4 (each within the scatter of the next).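

Every earlier compound carried nitro, so this place on the aromatic ring had not been tested. In this assay the exchange for trifluoromethyl gives a 1.0-fold higher number from compound 1 to compound 4 (0.02 log units; within the scatter) and so stays within the scatter, although nitro has 2 hydrogen-bond acceptors and trifluoromethyl has 0. No measurement here offers an explanation for this. Among the compounds shown here, the exchange is seen only with the nitrogen group of compound 1, so whether it would behave alike with the group on the nitrogen of compound 2 stays open. As far as these compounds go, how a nitrile, an amine or a carboxylic acid would read at this place also stays open.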